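Series notes: 4-hydroxybenzyl to 4-bromobenzyl step

The source may hold more compounds than are shown below. What is called first, only, known or untested is meant among the compounds shown, and "the series" means these compounds.

Measured compounds:
compound 1 `CCCSc1nc(N/N=C(\C)c2ccccc2O)c2nnn(Cc3ccc(O)cc3)c2n1` gives 15900 nM
compound 2 `CCCSc1nc(N/N=C(\C)c2ccccc2)c2nnn(Cc3ccccc3)c2n1` gives 32200 nM
compound 3 `CCCSc1nc(N/N=C/c2ccccc2)c2nnn(Cc3ccccc3)c2n1` reaches only a limit, > 64000 nM

In a functional assay on ECa-109 cells (Homo sapiens) for antiproliferative activity, read by MTT assay, with a stated time of 72 h (on this read-out lower numbers stand for stronger inhibition and higher numbers for weaker inhibition), compound 1 holds the lowest of the two numbers shown. Compound 2 sits higher, and that gap lies beyond the scatter. Compound 3 gives a limit rather than a number. Within the data shown here, the only single-point step measured so far, an at least 1.9-fold higher number from compound 2 to compound 3 (0.29 log units; that floor lies within the scatter), concerns the group on the hydrazone nitrogen and has a floor that lies within the scatter; it is bounded by the limit of > 64000 nM in this assay, at which 1 of the 3 values shown sits.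

Compound 4 `CCCSc1nc(N/N=C(\C)c2ccccc2O)c2nnn(Cc3ccc(Br)cc3)c2n1` is the next entry. It differs from compound 1 by bromo in place of hydroxy on an aromatic carbon. Among the measured compounds shown here, none of the measured steps touches the substituent on the benzyl group: the step from compound 2 to compound 3 changes the hydrazone side, and the pair compound 1 and compound 2 differ in two places at once, so no clean step on this position is available. With nothing bearing directly on the change, the working expectation is that the number for compound 4 stays close to compound 1, with no step beyond the scatter, so a 1.0-fold higher number from compound 1 to compound 4 (0.00 log units; within the scatter) is the estimated move. Compound 4 is estimated at 16000 nM, with a range from 6000 nM to 45000 nM.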

Compound 4, half-maximal inhibitory concentration: 36100 nM
The estimate for compound 4 lay 2.3-fold (0.35 log units) below the measured number; measured number inside the range.
By their numbers in this assay, from the lowest: compound 1; then compounds 2 and 4 (each within the scatter of the next). At a limit, above all of these: compound 3.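

In this assay, the substituent on the benzyl group proves able to move the number with the hydrazone side held constant: bromo in place of hydroxy gives a 2.3-fold higher number from compound 1 to compound 4 (0.36 log units; beyond the scatter). Among these compounds, this is the first clean single-point step at this position, and although modest, it favours hydroxy over bromo at this place, para to a large group, with the lower number staying with compound 1. The change swaps a group with hydrogen-bond donor and acceptor counts for one with neither, but nothing measured in this set gives a reason for the step.

From the compounds shown here alone, two readings remain open: the step could reflect the loss of hydroxy or the arrival of bromo, and a 4-methoxybenzyl, 4-aminobenzyl or 4-chlorobenzyl group on the core of compound 1 would help to tell these apart. Going by these compounds, it also remains open whether the same substituent change would give a step of similar size on the hydrazone side of compound 2, which lacks the hydroxy group on its phenyl ring.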